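The compounds below may be only part of what the source reports. "The series", "measured", "known", "first", "only" and "open" are said of these compounds alone.

In a functional assay on HT-29 cells (Homo sapiens) for inhibition, read by luminescence and CellTiter-Glo, with a stated time of 24 h (a higher number here means that more compound is needed for the effect, a lower number that less compound is needed), compound 1 `CCn1nc(C(=O)N[C@H]2COc3ccccc3N(C)C2=S)nc1Cc1ccccc1` with ethyl on an aromatic nitrogen gives 17 nM while compound 2 `CCCCn1nc(C(=O)N[C@H]2COc3ccccc3N(C)C2=S)nc1Cc1ccccc1` with butyl gives 510 nM and compound 3 `CN1C(=S)[C@@H](NC(=O)c2nc(Cc3ccccc3)n(C3CCCCCC3)n2)COc2ccccc21` with cycloheptyl gives 5530 nM as the highest number of the three. Across these compounds the number rises as the group grows, and none goes against this. Compound 4 `CN1C(=S)[C@@H](NC(=O)c2nc(Cc3ccccc3)n(CC3COC3)n2)COc2ccccc21` has (oxetan-3-yl)methyl in place of cycloheptyl on that aromatic nitrogen (oxetan-3-yl)methyl in place of cycloheptyl on an aromatic nitrogen and so changes the same place. The relevant steps are a 30-fold higher number from compound 1 to compound 2 (1.48 log units; beyond the scatter) and an 11-fold higher number from compound 2 to compound 3 (1.04 log units; beyond the scatter) and a 330-fold higher number from compound 1 to compound 3 (2.51 log units; beyond the scatter) and all three are large. The new group is smaller than cycloheptyl but brings an oxygen absent from the measured groups, so a large step to a lower number is expected in this assay with less certainty about its size. The estimated change is an 18-fold lower number from compound 3 to compound 4 (1.27 log units; beyond the scatter) and it remains an expectation. The value estimated for compound 4 is 300 nM within an expected range of 50 nM to 1800 nM until a measurement is available.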

Compound 4, half-maximal effective concentration: 2830 nM
Compound 4: middle estimate off by 9.4-fold (0.97 log units), on the low side; the whole stated range lies below it.
By their numbers in this assay, from the lowest: compound 1; then compound 2; then compounds 4 and 3 (each within the scatter of the next).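

Putting (oxetan-3-yl)methyl in place of cycloheptyl gives a 2.0-fold lower number from compound 3 to compound 4 (0.29 log units; within the scatter) and so the two cannot be told apart, even though the entering group has fewer heavy atoms and carries an oxygen. The straight chains still do better on this aromatic nitrogen, with a 5.5-fold higher number from compound 2 to compound 4 (0.74 log units; beyond the scatter) and a 170-fold higher number from compound 1 to compound 4 (2.22 log units; beyond the scatter) as the steps to the oxetane compound. Having fewer heavy atoms than cycloheptyl and an oxygen is therefore not enough here to reach the low number seen with ethyl.

From the compounds shown here alone, whether methyl, or a short chain ending in an amine, would fare better than ethyl stays open. Nothing available explains why the number moves with the group at this position.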